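Swapping Benzoyl for Sulfamoyl on a Weak Inhibitor

The source may hold more compounds than are shown below. What is called first, only, known or untested is meant among the compounds shown, and "the series" means these compounds.

Compound 2 `O=C(NC[C@H]1CC[C@H](C(=O)/C(=N/O)Nc2ccc(F)c(Br)c2)CC1)c1ccccc1` gives 81000 nM in an assay for inhibition of Tryptophan 2,3-dioxygenase (Homo sapiens), with a stated time of 1 h; on this read-out lower numbers stand for stronger inhibition and higher numbers for weaker inhibition. Compound 1 `O=C(Nc1ccccc1)[C@H]1CC[C@H](C(=O)/C(=N/O)Nc2ccc(F)c(Br)c2)CC1` reaches only a limit of the assay, > 100000 nM, as recorded in the limit of > 100000 nM in this assay, at which 1 of the 2 values shown sits. Among the measured compounds shown here, compound 2 thus holds the only actual number among the two values, the other being a limit. For the measured compounds named here, the one measured step, an at least 1.2-fold lower number from compound 1 to compound 2 (0.09 log units; that floor lies within the scatter), lies within the scatter. Compound 3 `NS(=O)(=O)NC[C@H]1CC[C@H](C(=O)/C(=N/O)Nc2ccc(F)c(Br)c2)CC1` differs from compound 2 by sulfamoyl in place of benzoyl on an amine nitrogen. Going by the values given here, no measured step touches this change, so the step from compound 2 to compound 3 cannot be read off from the data. Both measured compounds sit at the weak end of this assay, and compound 3 is expected to stay there, with a 1.2-fold higher number from compound 2 to compound 3 (0.09 log units; within the scatter) meaning no change beyond the scatter. Compound 3 is therefore estimated at 100000 nM, within 30000 nM to 300000 nM, with a real chance that only a limit is reported.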

Compound 3, half-maximal inhibitory concentration: 58700 nM
The estimate for compound 3 lay 1.7-fold (0.23 log units) above the measured number; low and high end bracket the measured number.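

Exchanging benzoyl for sulfamoyl on the amine nitrogen gives a 1.4-fold lower number from compound 2 to compound 3 (0.14 log units; within the scatter), so in this assay this position accepts a group without a ring as well as one with an aromatic ring, with no difference beyond the scatter. The wider change, (sulfamoylamino)methyl in place of phenylcarbamoyl on a saturated ring carbon, gives an at least 1.7-fold lower number from compound 1 to compound 3 (0.23 log units; that floor lies within the scatter). Compound 1 remains a limit of the assay and not a number: the limit of > 100000 nM in this assay, at which 1 of the 3 values shown sits.

Still open, going by these compounds, is whether any group on this amine nitrogen, such as an acetyl group, a carboxylic acid or a longer chain, can move the number beyond the scatter. Also open, on these data alone, is whether a change on the 4-fluoro-3-bromophenyl side, rather than on this nitrogen, would do so.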